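The compounds below may be only part of what the source reports. "The series", "measured", "known", "first", "only" and "open" are said of these compounds alone.

Measured in an ADME assay on HeLa cells (Homo sapiens) for cytotoxicity, read by sulforhodamine B assay, with a stated time of 48 h, tested at 10 uM; a higher number here means more inhibition at the concentration tested (going by the name of the read-out), a lower number less inhibition:
compound 1 `CCCCCCCc1cn(C(c2ccccc2)c2cc3cc(Br)ccc3nc2OC)nn1` gives 9.7%
compound 2 `COc1nc2ccc(Br)cc2cc1C(c1ccccc1)n1cc(-c2ccccc2)nn1` gives 13.9%
compound 3 `CCCc1cn(C(c2ccccc2)c2cc3cc(Br)ccc3nc2OC)nn1` gives -2.25%

Compound 1 stands second highest of the three. Nearest is compound 2, with a number 4.2 percentage points higher from compound 1 to compound 2 (within the scatter); furthest is compound 3, with a number 12 percentage points lower from compound 1 to compound 3 (beyond the scatter). Compound 4 `COc1nc2ccc(Br)cc2cc1C(c1ccccc1)n1cc(-c2cccc(F)c2)nn1` is not yet measured in this assay. Against compound 1 it shows (3-fluorophenyl in place of heptyl on an aromatic carbon). The step that bears on this most directly already swapped the same heptyl for a plain phenyl, a number 4.2 percentage points higher from compound 1 to compound 2 (within the scatter), a change within the scatter. The other two steps, a number 12 percentage points lower from compound 1 to compound 3 (beyond the scatter) and a number 16.2 percentage points lower from compound 2 to compound 3 (beyond the scatter), each put a smaller group at that aromatic carbon and went down by a modest amount. Among the compounds with values here, no measured step separates a fluorophenyl from a phenyl, so the expected step of a number 3.3 percentage points higher from compound 1 to compound 4 (within the scatter) is small, upward if anything, and within the scatter. Compound 4 is estimated at 13%, in the range 0% to 26%.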

Compound 4, a percentage reported as inhibition, at one concentration (the size of the read-out at that concentration, not a potency): 9.04%
The estimate for compound 4 lay 4 percentage points above the measured number; the range from low to high includes it.
By their numbers in this assay, from the lowest: compound 3; then compounds 4, 1 and 2 (each within the scatter of the next).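

In this assay, fluoro in place of hydrogen on the phenyl group gives a number 4.9 percentage points lower from compound 2 to compound 4 (within the scatter), so this change shows no readable effect. With 3-fluorophenyl in place of heptyl the step is a number 0.7 percentage points lower from compound 1 to compound 4 (within the scatter), while with 3-fluorophenyl in place of propyl it is a number 11.3 percentage points higher from compound 3 to compound 4 (beyond the scatter), which leaves compound 3 as the only one set apart at this aromatic carbon. No measured property is available to account for these steps. Still open, on these data alone, is what an amine or a carboxylic acid on that aromatic carbon would give.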